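A few compounds are considered here, and "the series" means these few. Any claim that something is new, unique, unknown or untested is made for them only; others in the source may bear on it.

Measured compounds:
compound 1 `Oc1c(C(c2ccc(F)cc2)N2CCCCC2)ccc2c1OCCO2` — 290 nM
compound 2 `Cc1ccc(C)c(C(Nc2ccccn2)c2ccc3cccnc3c2O)c1` — 730 nM
compound 3 `Oc1c(C(c2ccc(F)cc2)N2CCCCC2)ccc2cnccc12` — 610 nM

In an assay for inhibition of protein disulfide-isomerase (Homo sapiens), with a stated time of 1 h (on this read-out higher numbers stand for weaker inhibition and lower numbers for stronger inhibition), compound 2 gives 730 nM, the highest of the three numbers. Compound 3 gives 610 nM, which lies within the scatter of compound 2; compound 1 gives 290 nM, a gap to compound 2 beyond the scatter. Among the measured compounds shown here, no pair of measured compounds differs in one place, so no step size is known for any single change.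

Compound 4 `CCc1ccc(C(Nc2ccccn2)c2ccc3cccnc3c2O)cc1` is not yet measured. It differs from compound 2 by 4-ethylphenyl in place of 2,5-dimethylphenyl on a saturated chain carbon bound to an aromatic carbon and a nitrogen on an aromatic ring. For the measured compounds named here, both groups carry the same atoms joined differently, and no measured pair speaks to such a rearrangement. The expected step from compound 2 to compound 4 in this assay is a 1.0-fold lower number from compound 2 to compound 4 (0.02 log units; within the scatter), with no clear direction beyond the scatter. Compound 4 is therefore estimated at 700 nM, range 300 nM to 1700 nM.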

Compound 4, half-maximal inhibitory concentration: 170 nM
The estimate for compound 4 lay 4.1-fold (0.61 log units) above the measured number, and the stated range ends above it.
By their numbers in this assay, from the lowest: compounds 4 and 1 (each within the scatter of the next); then compounds 3 and 2 (each within the scatter of the next).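

In this assay, among the compounds shown here, 4-ethylphenyl in place of 2,5-dimethylphenyl on the saturated chain carbon gives a 4.3-fold lower number from compound 2 to compound 4 (0.63 log units; beyond the scatter) as the first single-change step. This position therefore responds to how the same atoms are joined, with no change in the counted make-up of the group. Nothing measured on these compounds explains the step.

As far as these compounds go, whether the step follows from the ethyl group or from the loss of the 2,5-dimethyl pattern stays open. A 4-methylphenyl, 2-methylphenyl or 4-propylphenyl group would help separate these, and a single pair gives no trend.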